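Methyl for Isopropyl: Estimating Compound 4

A few compounds are considered here, and "the series" means these few. Any claim that something is new, unique, unknown or untested is made for them only; others in the source may bear on it.

Measured so far:
- compound 1, `C[C@H](NC(=O)CN(c1nc(Cl)nc2[nH]cnc12)C1CC1)C(=O)O`, gives 28.4% in a functional assay on the whole organism (Tail, strain ICR) with Mus musculus as the target, in the tail flick test, with a stated time of 120 min, at a dose of 25 umol/kg by the oral route; on this read-out lower numbers stand for a weaker effect and higher numbers for a stronger effect at the one dose given
- compound 2, `O=C(CN(c1nc(Cl)nc2[nH]cnc12)C1CC1)N[C@@H](CCC(=O)OCc1ccccc1)C(=O)OCc1ccccc1`, gives 45.9% in this assay
- compound 3, `CC(C)[C@H](NC(=O)CN(c1nc(Cl)nc2[nH]cnc12)C1CC1)C(=O)OCc1ccccc1`, gives 27.3% in this assay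

Compound 3 has the lowest of the three numbers. Its nearest neighbour is compound 1, which sits within the usual scatter of it, so no order between the two can be read; compound 2 lies beyond the scatter above compound 3.

Compound 4, `C[C@H](NC(=O)CN(c1nc(Cl)nc2[nH]cnc12)C1CC1)C(=O)OCc1ccccc1`, differs from compound 3 in one place: methyl in place of isopropyl on a saturated chain carbon bound to an amide-type nitrogen and a carbonyl carbon. Going by the values given here, only one measured step exists at that place, a number 18.6 percentage points lower from compound 2 to compound 3 (beyond the scatter), and it concerns a different exchange, so it offers no direct guide to the present change. What can be used is that compound 1 already carries the methyl of compound 4, though with a free acid where compound 4 has a benzyl ester, and the values of compound 1 and compound 3 lie within the scatter of one another.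

Compound 4 is therefore expected to stay near compound 3, with a step of a number 2.7 percentage points higher from compound 3 to compound 4 (within the scatter) that would not exceed the scatter. The estimate for compound 4 is 30%, with a range from 17% to 45%.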

Compound 4, a percentage reported as activity, at one dose (the size of the read-out at that dose, not a potency): 36.1%
Estimate against measurement, compound 4: 6.1 percentage points below; the range from low to high includes it.
By their numbers in this assay, from the lowest: compounds 3, 1, 4 and 2 (each within the scatter of the next, the first and the last beyond it).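

Exchanging isopropyl for methyl on a saturated chain carbon bound to an amide-type nitrogen and a carbonyl carbon, which takes 3 heavy atoms down to 1, gives a number 8.8 percentage points higher from compound 3 to compound 4 (within the scatter) in this assay and so does not separate the two compounds on this read-out. The longer side chain fares no differently, since hydrogen in place of (benzyloxycarbonyl)methyl gives a number 9.8 percentage points lower from compound 2 to compound 4 (within the scatter) and compound 4 therefore lies within the scatter of both compounds whose own gap, a number 18.6 percentage points lower from compound 2 to compound 3 (beyond the scatter), goes beyond it. With methyl on this carbon, the ester is also not separated from the free acid, as benzyl in place of hydrogen on an oxygen next to a carbonyl group gives a number 7.7 percentage points higher from compound 1 to compound 4 (within the scatter) and the benzyl group on that oxygen thus shows no effect that can be read from this pair.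

As far as these compounds go, whether an amine at the end of a longer chain on this carbon would stand apart from these four values remains open. Nothing available here offers an explanation for the differences that are seen among these compounds.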